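The compounds below may be only part of what the source reports. "The series", "measured", "known", "first", "only" and "open" are said of these compounds alone.

Measured compounds: compound 1 `CCCC[C@]1(CC)CS(=O)(=O)c2ccc(N)cc2[C@@H](c2ccccc2)[C@H]1O` gives 68 nM in an assay on cells for inhibition of ileal sodium/bile acid cotransporter (Homo sapiens); on this read-out higher numbers stand for weaker inhibition and lower numbers for stronger inhibition; compound 2 `CCCC[C@]1(CC)CS(=O)(=O)c2ccc(NO)cc2[C@@H](c2ccccc2)[C@H]1O` gives 260 nM in this assay.

Going by the values given here, compound 2 has the higher of the two numbers; the one step recorded, a 3.8-fold higher number from compound 1 to compound 2 (0.58 log units; beyond the scatter), introduced a hydroxy onto the nitrogen on the aromatic ring and so left compound 2 the weaker inhibitor of the pair.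

Compound 3 `CCCC[C@]1(CC)CS(=O)(=O)c2ccc(N(O)C(=O)OC(C)(C)C)cc2[C@@H](c2ccccc2)[C@H]1O` continues along that nitrogen: tert-butoxycarbonyl in place of hydrogen on a nitrogen on an aromatic ring. Among the compounds with values here, no measured step describes adding a tert-butoxycarbonyl to this nitrogen, so the only guide is indirect. The sole related observation, a 3.8-fold higher number from compound 1 to compound 2 (0.58 log units; beyond the scatter), shows that building out this nitrogen cost potency by a modest margin. Adding a further, larger group there is expected to carry a similar or somewhat greater penalty, but the expectation is loosely held.

For compound 3 the estimate in this assay is 600 nM, within 150 nM to 2500 nM, corresponding to an expected step of a 2.3-fold higher number from compound 2 to compound 3 (0.36 log units; beyond the scatter).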

Compound 3, half-maximal inhibitory concentration: 2670 nM
Compound 3: the middle estimate sits 4.5-fold (0.65 log units) below what was measured; the whole stated range lies below it.
By their numbers in this assay, from the lowest: compound 1; then compound 2; then compound 3.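

In this assay, the nitrogen on the aromatic ring tolerates a tert-butoxycarbonyl far less well than it tolerates a hydroxy: the new change gives a large loss (a 10-fold higher number from compound 2 to compound 3 (1.01 log units; beyond the scatter)), whereas the earlier one was modest (a 3.8-fold higher number from compound 1 to compound 2 (0.58 log units; beyond the scatter)). Both changes together take the series a long way from the plain amino group (a 39-fold higher number from compound 1 to compound 3 (1.59 log units; beyond the scatter)), leaving compound 1 the strongest inhibitor of the three and compound 3 the weakest. So far, each group added to this nitrogen has raised the number, and the larger group has raised it more, but nothing available explains why this position responds this way.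

On these data alone, whether a smaller group such as acetyl or methyl on this nitrogen would cost as much remains open. So does the cost of tert-butoxycarbonyl on a nitrogen carrying no hydroxy.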